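Stereochemical inversion from compound 2 to compound 3

The compounds below may be only part of what the source reports. "The series", "measured", "known", "first", "only" and "open" are said of these compounds alone.

Compound 1 `Cc1nsc2c1ncn2[C@H]1C[C@H](O)[C@@H](CO)O1` gives in a functional assay on HFF cells (Homo sapiens) for inhibition (on this read-out lower numbers stand for stronger inhibition and higher numbers for weaker inhibition), a value that is an assay limit, > 100000 nM. Compound 2 `Cc1nsc2c1ncn2[C@@H]1O[C@H](CO)[C@@H](O)[C@@H]1O` likewise returns only a limit in this assay, > 100000 nM. Among the compounds with values here, the single recorded step, a step that the two limits leave unreadable from compound 1 to compound 2, cannot be read because of the limit of > 100000 nM in this assay, at which 2 of the 2 values shown sit. Compound 3 `Cc1nsc2c1ncn2[C@@H]1O[C@H](CO)[C@@H](O)[C@H]1O` differs from compound 2 only in configuration: the two compounds have the same atoms and bonds and differ only in configuration as drawn: 1 of 4 stereo elements differ; a stereocentre at a saturated ring carbon is drawn S in compound 2 and R in compound 3. Within the data shown here, no measured step bears on such a change, and with both neighbours at the limit no direction beyond the scatter can be drawn. Compound 3 is therefore expected to stay at the limit, the estimated step being a number no higher from compound 2 to compound 3 (the limit leaves the size open). The estimate for compound 3 is 100000 nM, with a range from 30000 nM to 300000 nM.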

Compound 3, half-maximal inhibitory concentration: 150000 nM
Beside the measured number, compound 3's estimate is 1.5-fold (0.18 log units) below it; the measured number falls inside the stated range.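

Compound 3 gives no readable step against compound 1 or compound 2 in this assay: the limit of > 100000 nM in this assay, at which 2 of the 3 values shown sit.

The compounds shown leave open whether the ring hydroxy or the drawn configuration changes inhibition at all.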